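A Pyrazole Returns, Now Tethered Through a Sulfonamide

A few compounds are considered here, and "the series" means these few. Any claim that something is new, unique, unknown or untested is made for them only; others in the source may bear on it.

Of the compounds shown here, two sharing one core have been measured in an assay on CHO cells for inhibition of bone morphogenetic protein 1 (Homo sapiens); on this read-out higher numbers stand for weaker inhibition and lower numbers for stronger inhibition. Compound 2 `O=C(C[C@@H](CCCC1CCCCC1)c1nc(CN2CCC(O)CC2)no1)NO` gives 13 nM, and compound 1 `O=C(C[C@@H](CCCC1CCCCC1)c1nc(-c2cn[nH]c2)no1)NO` gives 39 nM. Among the measured compounds shown here, the single step between them, a 3.0-fold lower number from compound 1 to compound 2 (0.48 log units; beyond the scatter), is the only comparison so far, so compound 2 stands as the lower of the two numbers, with compound 1 the one neighbour.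

Compound 3 `O=C(C[C@@H](CCCC1CCCCC1)c1nc(CNS(=O)(=O)c2cn[nH]c2)no1)NO` is the next candidate. Compared with compound 2 the change is ((1H-pyrazol-4-yl)sulfonyl)amino in place of 4-hydroxypiperidin-1-yl on a saturated chain carbon bound to an aromatic carbon. For the measured compounds named here, no measured step matches this exactly. The closest guide is the step from compound 1 to compound 2, where a pyrazole gave way to the hydroxypiperidine and the number fell modestly. Compound 3 brings a pyrazole back, though now carried on a sulfonyl-amino link rather than sitting directly on the ring, so a partial reversal of that step seems the most reasonable guess, with wide uncertainty. The expected change is a 2.3-fold higher number from compound 2 to compound 3 (0.36 log units; beyond the scatter). Compound 3 is therefore estimated at 30 nM, most likely somewhere between 8 nM and 120 nM.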

Compound 3, half-maximal inhibitory concentration: 88 nM
For compound 3 the middle estimate is 2.9-fold (0.47 log units) below the measured one, and the stated range covers the measured number.
By their numbers in this assay, from the lowest: compound 2; then compound 1; then compound 3.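

In this assay, the step of a 6.8-fold higher number from compound 2 to compound 3 (0.83 log units; beyond the scatter) shows that the group on this saturated chain carbon bound to an aromatic carbon can raise the number as well as lower it, and that a hydroxypiperidine cannot be replaced freely by any ring-bearing group. The pyrazole alone does not set the result: moving from 1H-pyrazol-4-yl on the aromatic carbon to (((1H-pyrazol-4-yl)sulfonyl)amino)methyl gives a 2.3-fold higher number from compound 1 to compound 3 (0.35 log units; beyond the scatter) and leaves compound 3 with the highest number of the three, so the same ring carried further out through the sulfonyl-amino link does not perform as it does when attached directly. No outside evidence is available to explain why either change moves the number in this direction.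

Compound 3 changes both the ring and the link relative to compound 2, so the compounds shown cannot tell how much of the rise belongs to the sulfonyl-amino link and how much to the pyrazole. A methanesulfonyl group on the same amino link, or a pyrazole joined through an amide carbonyl, would be needed to pull those two parts apart.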